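The compounds below may be only part of what the source reports. "The series", "measured", "known", "first", "only" and "open" are said of these compounds alone.

Three measured compounds:

- compound 1, `Clc1cccc(CSc2nnc(-c3ccncc3)n2-c2ccccc2)c1`, which in a functional assay on HepG2 cells (Homo sapiens) for inhibition, read by MTT assay, with a stated time of 48 h (a higher number here means a weaker inhibitor, a lower number a stronger inhibitor), gives 11200 nM
- compound 2, `Fc1ccc(CSc2nnc(-c3ccncc3)n2-c2ccccc2)c(F)c1`, which in this assay gives 10200 nM
- compound 3, `O=C(CSc1nnc(-c2ccncc2)n1-c1ccccc1)N/N=C/c1ccccc1`, which in this assay gives 18600 nM

All three share the same core and differ only in the group carried on the sulfur. Their three numbers lie within the usual scatter of one another, so compound 3 cannot be set apart from compound 1 or from compound 2 on these data.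

Compound 4, `O=C(CSc1nnc(-c2ccncc2)n1-c1ccccc1)N/N=C/c1ccc([N+](=O)[O-])cc1`, has not yet been measured. It differs from compound 3 by nitro in place of hydrogen on an aromatic carbon. Among the measured compounds shown here, the only step measured so far, a 1.1-fold lower number from compound 1 to compound 2 (0.04 log units; within the scatter), also swapped substituents on an outer aromatic ring and did not move the number. That step is the nearest guide, though it concerns a different group on a different ring, so it is a weak one. On this basis no step beyond the scatter is expected for compound 4 in this assay, that is a 1.0-fold lower number from compound 3 to compound 4 (0.01 log units; within the scatter). Compound 4 is therefore estimated at 18000 nM, with a range from 8000 nM to 40000 nM.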

Compound 4, half-maximal inhibitory concentration: 15900 nM
Beside the measured number, compound 4's estimate is 1.1-fold (0.05 log units) above it; measured number inside the range.
By their numbers in this assay, from the lowest: compounds 2, 1, 4 and 3 (each within the scatter of the next).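

Putting nitro in place of hydrogen on this phenyl ring gives, in this assay, a 1.2-fold lower number from compound 3 to compound 4 (0.07 log units; within the scatter). This is the first change shown on this ring, and it shows that a group of 3 heavy atoms, with 2 hydrogen-bond acceptors, can replace a lone hydrogen there without a step beyond the scatter. The data shown offer no measurement that could explain this result.

The compounds shown leave open whether an amine or a carboxylic acid at this same place, or a nitro group elsewhere on the phenyl ring, would give a step beyond the scatter. No step shown so far lies beyond the scatter, so it also remains unknown which part of these structures, if any, governs the number in this assay.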